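Heteroaryl exchange on the central carbon of compound 2

The compounds below may be only part of what the source reports. "The series", "measured", "known", "first", "only" and "open" are said of these compounds alone.

The series is read in an ADME assay on L6 cells (Rattus norvegicus) for cytotoxicity, read by resazurin assay, with a stated time of 72 h; on this read-out higher numbers stand for weaker inhibition and lower numbers for stronger inhibition. Compound 1 `OC(c1ccc(Cl)cc1)(c1ccc(Cl)cc1)c1cncnc1` gives 47200 nM and compound 3 `OC(c1ccc(Cl)cc1)(c1ccc(Br)cc1)c1cncnc1` gives 58700 nM, a difference of a 1.2-fold higher number from compound 1 to compound 3 (0.09 log units; within the scatter). For compound 2 `OC(c1ccc(Cl)cc1)(c1cncnc1)c1cccc(F)c1` only a limit of the assay is recorded, > 100000 nM, so its position is known as a floor only (the limit of > 100000 nM in this assay, at which 1 of the 3 values shown sits). The step from compound 1 is an at least 2.1-fold higher number from compound 1 to compound 2 (0.32 log units; beyond the scatter), and from compound 2 onward to compound 3 the step is an at least 1.7-fold lower number from compound 2 to compound 3 (0.23 log units; that floor lies within the scatter).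

Compound 4 `OC(c1ccc(Cl)cc1)(c1cccnc1)c1cccc(F)c1` has not been measured. It differs from compound 2 by pyridin-3-yl in place of pyrimidin-5-yl on a saturated chain carbon bound to two aromatic carbons and an oxygen on a saturated carbon. Among the compounds with values here, none of the measured steps touches this position: the three steps recorded all concern the two carbon-only aryl groups on the same saturated carbon, and each of them stays within or just beyond the scatter. No measured comparison therefore bears on the exchange of the heteroaryl group, and no step beyond the scatter is expected in either direction in this assay.

On that basis compound 4 is expected to give about 100000 nM, between 45000 nM and 250000 nM, meaning an estimated step of a number no higher from compound 2 to compound 4 (the limit leaves the size open) relative to the floor of compound 2, with a real chance that the assay again returns only a limit.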

Compound 4, half-maximal inhibitory concentration: 66000 nM
The estimate for compound 4 lay 1.5-fold (0.18 log units) above the measured number, and the stated range covers the measured number.
By their numbers in this assay, from the lowest: compounds 1, 3 and 4 (each within the scatter of the next). At a limit, above all of these: compound 2.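

Within the data shown here, exchanging pyrimidin-5-yl for pyridin-3-yl on the saturated chain carbon gives the only reading in this assay that touches the heteroaryl group: an at least 1.5-fold lower number from compound 2 to compound 4 (0.18 log units; that floor lies within the scatter). With pyridin-3-yl in place, compound 4 returns a number rather than a limit, so this change brings the read-out into the range that can be compared with the rest of the series. Compound 2 is recorded only as a limit of the assay, > 100000 nM, so the true size of the step stays unknown, and its floor does not establish a change beyond the scatter: the limit of > 100000 nM in this assay, at which 1 of the 4 values shown sits.

The compounds shown leave open whether the same exchange would read alike with the two aryl groups of compound 1 or compound 3, since only the pair of compound 2 and compound 4 carries it. They also leave open how the read-out responds when the heteroaryl group on this carbon gives way to a plain phenyl ring, or to a pyridine ring carrying an amine.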